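The compounds below may be only part of what the source reports. "The series", "measured", "known", "first", "only" and "open" are said of these compounds alone.

Of the compounds shown here, three sharing one core have been tested in an ADME assay on PC-3 cells (Homo sapiens) for cytotoxicity, read by sulforhodamine B assay, with a stated time of 48 h, tested at 10 uM; on this read-out lower numbers stand for less inhibition and higher numbers for more inhibition at the one concentration tested (going by the name of the read-out). Compound 1 `COc1nc2ccc(Br)cc2cc1C(c1ccccc1)n1cc(-c2ccc(Br)cc2)nn1` gives 7.43%. Compound 2 `CCOC(=O)c1cn(C(c2ccccc2)c2cc3cc(Br)ccc3nc2OC)nn1` gives 16.1%. Compound 3 `COc1nc2ccc(Br)cc2cc1C(c1ccccc1)n1cc(-c2ccc(OC(F)(F)F)cc2)nn1` gives 21.6%. Compound 3 holds the highest of the three numbers, but the gap to compound 2 is within the scatter, while the step of a number 14.2 percentage points higher from compound 1 to compound 3 (beyond the scatter) is a modest one beyond it. All three numbers are low on this read-out.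

Compound 4 `COc1nc2ccc(Br)cc2cc1C(c1ccccc1)n1cc(CCO)nn1` has not yet been measured. It differs from compound 3 in one place: 2-hydroxyethyl in place of 4-(trifluoromethoxy)phenyl on an aromatic carbon. Two earlier steps changed the group at this same carbon of the five-membered ring. Ethoxycarbonyl in place of 4-bromophenyl gave a number 8.7 percentage points higher from compound 1 to compound 2 (within the scatter), and 4-(trifluoromethoxy)phenyl in place of ethoxycarbonyl gave a number 5.5 percentage points higher from compound 2 to compound 3 (within the scatter). Neither moved this assay beyond its usual spread, so swapping groups here has so far left the numbers in the same low region. The 2-hydroxyethyl group is a new kind of group at this place, with a hydrogen-bond donor the others lack, and nothing measured speaks directly to it. The expected step is therefore a number 8.6 percentage points lower from compound 3 to compound 4 (within the scatter), none beyond the scatter. Compound 4 is estimated to give 13% in this assay, within a range from 0% to 28%.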

Compound 4, a percentage reported as inhibition, at one concentration (the size of the read-out at that concentration, not a potency): 15.5%
Compound 4: middle estimate off by 2.5 percentage points, on the low side; low and high end bracket the measured number.
By their numbers in this assay, from the lowest: compounds 1, 4, 2 and 3 (each within the scatter of the next, the first and the last beyond it).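

In this assay, this carbon of the five-membered ring now carries a short open chain instead of an aromatic ring or an ester, and the number stays in the same low region: there is a number 6.1 percentage points lower from compound 3 to compound 4 (within the scatter) when 2-hydroxyethyl replaces 4-(trifluoromethoxy)phenyl, a number 0.6 percentage points lower from compound 2 to compound 4 (within the scatter) when it replaces ethoxycarbonyl, and a number 8.1 percentage points higher from compound 1 to compound 4 (within the scatter) when it replaces 4-bromophenyl. A group of 3 heavy atoms with 1 hydrogen-bond donor, taking the place of one of 11 heavy atoms with none, therefore gives no step beyond the scatter from any of the three earlier compounds, so compound 4 cannot be separated from any of them in this assay. Nothing measured here explains why the numbers stay so close together at this carbon.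

Going by these compounds, whether any group at this carbon can lift the number clear of this low region remains open, as does whether the hydroxyl of compound 4 matters at all. An amine or a carboxylic acid on the same two-carbon chain, or a longer chain ending in a hydroxyl, would test this directly against compound 4.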